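From Pyridazin-3-yl to 5-Methyl-1,3,4-oxadiazol-2-yl

The compounds below may be only part of what the source reports. "The series", "measured", "known", "first", "only" and "open" are said of these compounds alone.

Of the compounds shown here, three have been measured in a physicochemical assay for lipophilicity, read by HPLC, measured as chromatographic lipophilicity, at pH 7.4; on this read-out higher numbers stand for higher lipophilicity and lower numbers for lower lipophilicity. Compound 1 `O=C(C1CCCCC1)N1N=CCC1c1ccccc1` gives 5.9, compound 2 `CC(C)(C)C(=O)N1N=CCC1c1c[nH]cn1` gives 1.7, and compound 3 `O=C(C1CCN(c2cccnn2)CC1)N1N=CC[C@H]1c1ccccc1` gives 3.4. Compound 3 therefore holds the second highest of the three numbers: compound 2 sits lower by a margin beyond the scatter, and compound 1 sits higher, also beyond the scatter. The next compound, compound 4 `Cc1nnc(N2CCC(C(=O)N3N=CC[C@H]3c3ccccc3)CC2)o1`, differs from compound 3 in one place: 5-methyl-1,3,4-oxadiazol-2-yl in place of pyridazin-3-yl on an amine nitrogen in a ring. Going by the values given here, no measured pair shows this change, so the step can only be estimated. The group leaving and the group entering carry the same count of heavy atoms. The step in this assay is expected to be small, with a number 0.20 log units lower from compound 3 to compound 4 (within the scatter) falling within the usual scatter. Compound 4 is therefore estimated at 3.2, in a range from 2.5 to 3.9.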

Compound 4, distribution coefficient: 3.2
Beside the measured number, compound 4's estimate shows no gap at the digits printed; the range from low to high includes it.
By their numbers in this assay, from the lowest: compound 2; then compounds 4 and 3 (each within the scatter of the next); then compound 1.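

In this assay, going by these compounds alone, this is the first pair of compounds that differ in one place, and it gives a number 0.20 log units lower from compound 3 to compound 4 (within the scatter). On this amine nitrogen in a ring, a five-membered aromatic ring with 3 hetero atoms can therefore replace a six-membered aromatic ring with 2 hetero atoms, and the read-out stays within the usual scatter. Nothing available explains why the two groups read so closely.

As far as these compounds go, it remains open whether an acetyl group or a plain alkyl chain on the same nitrogen would also stay this close. A single pair also cannot show whether the same change behaves this way on other cores.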